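A few compounds are considered here, and "the series" means these few. Any claim that something is new, unique, unknown or untested is made for them only; others in the source may bear on it.

Compound 2 `CC1(C)C=C(n2ccccc2=O)c2cc(Br)ccc2O1` is the stronger of the two compounds measured in a functional assay (aorta) with Rattus norvegicus as the target; on this read-out higher numbers stand for higher potency (the scale is a negative logarithm) and lower numbers for lower potency; compound 2 gives 7.84, while compound 1 `CC1(C)C=C(n2ccccc2=O)c2cc(C(=O)c3ccco3)ccc2O1` gives 6.49. Going by the values given here, the one measured step, a number 1.35 log units higher from compound 1 to compound 2 (beyond the scatter), replaced a larger ring-bearing group with bromo and raised potency. Compound 3 `CC1(C)C=C(n2ccccc2=O)c2cc(C(F)(F)F)ccc2O1` differs from compound 2 by trifluoromethyl in place of bromo on an aromatic carbon. Among the compounds with values here, no measured step touches trifluoromethyl, so that step is only a loose guide; the swap keeps zero hydrogen-bond donors and acceptors at the same place. A step of a number 0.24 log units lower from compound 2 to compound 3 (within the scatter) is expected, within the scatter. Compound 3 is estimated at 7.6, between 6.9 and 8.3.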

Compound 3, logarithm of the reciprocal of the active concentration, log(1/C): 7.61
Beside the measured number, compound 3's estimate is 0.01 log units below it, within the range that was stated.
By their numbers in this assay, from the lowest: compound 1; then compounds 3 and 2 (each within the scatter of the next).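

With a number 0.23 log units lower from compound 2 to compound 3 (within the scatter) for trifluoromethyl in place of bromo, the two groups cannot be told apart at this position in this assay on these numbers. The advantage over (furan-2-yl)carbonyl therefore does not belong to bromo alone, as a number 1.12 log units higher from compound 1 to compound 3 (beyond the scatter) shows. Why bromo and trifluoromethyl read alike stays unexplained, as no measurement given here speaks to it. Still open, from the compounds shown here alone, is how a plain hydrogen, a methoxy group, an amine or a carboxylic acid would fare on this aromatic carbon. Also open, going by these compounds, is whether potency falls gradually as the group grows from trifluoromethyl toward (furan-2-yl)carbonyl.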